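Moving the methyl from oxygen to nitrogen on a hydroxamate

The source may hold more compounds than are shown below. What is called first, only, known or untested is meant among the compounds shown, and "the series" means these compounds.

Compound 2 `CONC(=O)[C@@H]1CC=C(CCC=C(C)C)C[C@H]1c1ccccc1` gives 2700 nM in an assay on isolated protein for inhibition of Apoptosis regulator Bcl-2 (Homo sapiens), read by fluorescence polarization, with stated times of 5 min and 10 min (on this read-out higher numbers stand for weaker inhibition and lower numbers for stronger inhibition), the highest of the two numbers reported; compound 1 `CC(C)=CCCC1=CC[C@H](C(=O)NO)[C@@H](c2ccccc2)C1` gives 600 nM. Compound 3 `CC(C)=CCCC1=CC[C@H](C(=O)Nc2ccc(O)cc2)[C@@H](c2ccccc2)C1` reaches only a limit, > 23000 nM. Compound 4 `CC(C)=CCCC1=CC[C@@H](C(=O)N(C)O)[C@H](c2ccccc2)C1` is not yet measured; it differs from compound 2 by hydroxy(methyl)amino in place of methoxyamino on a carbonyl carbon. Among the compounds with values here, the one measured step, an at least 38-fold higher number from compound 1 to compound 3 (1.58 log units; beyond the scatter), concerns a different substituent on the amide-type nitrogen and bears on compound 4 only by showing that this position is sensitive. Compound 1 and compound 2 show that a methyl on the hydroxy weakens inhibition. Compound 4 keeps a free hydroxy, so compound 4 is expected to land between the two, estimated at 1500 nM (range 500 nM to 5000 nM), a step of a 1.8-fold lower number from compound 2 to compound 4 (0.26 log units; within the scatter).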

Compound 4, inhibition constant: 2300 nM
Compound 4: middle estimate off by 1.5-fold (0.19 log units), on the low side, within the range that was stated.
By their numbers in this assay, from the lowest: compound 1; then compounds 4 and 2 (each within the scatter of the next). At a limit, above all of these: compound 3.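

The step (a 1.2-fold lower number from compound 2 to compound 4 (0.07 log units; within the scatter)) shows that in this assay it makes no readable difference whether the methyl sits on the oxygen or on the nitrogen of this group on the carbonyl carbon. A free hydroxy alone therefore does not give the lower number: compound 1 gives 600 nM while compound 4, which keeps the hydroxy and carries the methyl on nitrogen, gives 2300 nM and stands with the higher values. Nothing measured here accounts for this. Still open, going by these compounds, is how a carboxylic acid or a primary amide would read on this carbonyl carbon. Also open, on these data alone, is what an ethyl on the nitrogen, or methyls on both nitrogen and oxygen, would give.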